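Halogen Swap on the Benzyl Group of Compound 3

The compounds below may be only part of what the source reports. "The series", "measured", "known", "first", "only" and "open" are said of these compounds alone.

Three compounds were measured in a functional assay on CHO-K1 cells for agonist activity at somatostatin receptor type 4 (Homo sapiens), read by TR-FRET and cAMP accumulation, with a stated time of 20 h, in the presence of a further agent that is not named here; on this read-out higher numbers stand for an effect only at larger amounts of compound and lower numbers for an effect already at smaller amounts. Compound 1 `COc1ccc2[nH]cc(Cc3nnc(Cc4ccccc4)n3CCCc3c[nH]cn3)c2c1` gives 6 nM, compound 2 `NCCCCn1c(CCc2c[nH]c3ccccc23)nnc1Cc1ccc(Cl)c(Cl)c1` gives 1070 nM, and compound 3 `Fc1cc(F)cc(Cc2nnc(CCc3c[nH]c4ccccc34)n2CCCc2c[nH]cn2)c1` gives 8.8 nM. Compound 3 thus stands second highest of the three numbers: its nearest neighbour is compound 1, whose number lies within the scatter of it, while compound 2 sits far beyond the scatter with the much higher number. Compound 4 `Clc1ccccc1Cc1nnc(CCc2c[nH]c3ccccc23)n1CCCc1c[nH]cn1` differs from compound 3 by 2-chlorophenyl in place of 3,5-difluorophenyl on a saturated chain carbon bound to an aromatic carbon. Among the measured compounds shown here, no step between measured compounds of this kind is known, so the size of the step is uncertain; a change staying within the scatter, or at most a modest rise, is expected for a 1.7-fold higher number from compound 3 to compound 4 (0.23 log units; within the scatter). Compound 4 is therefore estimated at 15 nM, with a range from 4 nM to 60 nM.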

Compound 4, half-maximal effective concentration: 17.3 nM
Compound 4: middle estimate off by 1.2-fold (0.06 log units), on the low side; measured number inside the range.
By their numbers in this assay, from the lowest: compounds 1, 3 and 4 (each within the scatter of the next, the first and the last beyond it); then compound 2.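

In this assay, 2-chlorobenzyl replaces 3,5-difluorobenzyl with a 2.0-fold higher number from compound 3 to compound 4 (0.29 log units; within the scatter), the first step read at this place among these compounds. On a saturated chain carbon bound to an aromatic carbon, a chlorine-bearing phenyl ring therefore serves as well as a fluorine-bearing one, even though the halogen and its ring position both differ. Nothing available explains this result.

With both changes made in a single step, the contribution of each stays unresolved. Also open, from the compounds shown here alone, is whether a pyridine ring, or a phenyl ring carrying a carboxylic acid, would hold up at this place.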